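Aryl variation at the hydrazone carbon: outlook for compound 4

The source may report more compounds than this note shows. Statements on the series, on what has been measured and on what is new or still open speak of the compounds shown alone.

Values in a functional assay on MKN-45 cells (Homo sapiens) for cytotoxicity, read by MTT assay, with a stated time of 72 h; a higher number here means a weaker inhibitor, a lower number a stronger inhibitor:
- compound 1 `COc1ccc(OC)c(/C=N/NC(=O)Nc2ccc(Oc3ccnc(-c4nncn4CCN(C)C)c3)c(F)c2)c1`: 1510 nM
- compound 2 `CN(C)CCn1cnnc1-c1cc(Oc2ccc(NC(=O)N/N=C/c3ccccc3O[N+](=O)[O-])cc2F)ccn1`: 1020 nM
- compound 3 `CN(C)CCn1cnnc1-c1cc(Oc2ccc(NC(=O)N/N=C/c3ccc(Cl)cc3)cc2F)ccn1`: 570 nM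

Compound 1 holds the highest number of the three. Its nearest neighbour is compound 2, with a 1.5-fold lower number from compound 1 to compound 2 (0.17 log units; within the scatter); its furthest is compound 3, with a 2.6-fold lower number from compound 1 to compound 3 (0.42 log units; beyond the scatter). Between the other two the step is a 1.8-fold lower number from compound 2 to compound 3 (0.25 log units; within the scatter).

Compound 4 `Cc1cc(/C=N/NC(=O)Nc2ccc(Oc3ccnc(-c4nncn4CCN(C)C)c3)c(F)c2)cc(C)c1O` differs from compound 1 in one place: 4-hydroxy-3,5-dimethylphenyl in place of 2,5-dimethoxyphenyl on a carbon with a double bond to nitrogen. Both measured steps out of compound 1 exchange the same 2,5-dimethoxyphenyl group on the carbon with a double bond to nitrogen, and both lower the number, one within the scatter and one modestly beyond it. The entering 4-hydroxy-3,5-dimethylphenyl group brings a hydrogen-bond donor, which neither compound 2 nor compound 3 tests, so no step larger than those two is indicated. The expectation for compound 4 in this assay is therefore a step of about a 1.4-fold lower number from compound 1 to compound 4 (0.14 log units; within the scatter), a small lowering or none beyond the scatter. Compound 4 is estimated at 1100 nM, with a range from 450 nM to 2800 nM.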

Compound 4, half-maximal inhibitory concentration: 1510 nM
Compound 4: the middle estimate sits 1.4-fold (0.14 log units) below what was measured; low and high end bracket the measured number.
By their numbers in this assay, from the lowest: compounds 3, 2, 1 and 4 (each within the scatter of the next, the first and the last beyond it).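

Exchanging 2,5-dimethoxyphenyl, with no hydrogen-bond donor, for 4-hydroxy-3,5-dimethylphenyl, with one, gives in this assay no change at the digits printed from compound 1 to compound 4 (within the scatter), so this position accepts a phenolic hydroxyl flanked by two methyl groups without a reading beyond the scatter, and the number stays where the two methoxy groups had it. The new aryl group also stays within the scatter of the 2-(nitrooxy)phenyl group, with a 1.5-fold higher number from compound 2 to compound 4 (0.17 log units; within the scatter), whereas 4-chlorophenyl remains apart, with a 2.6-fold higher number from compound 3 to compound 4 (0.42 log units; beyond the scatter), so among these four compounds the only steps beyond the scatter are those from compound 3 to compounds 1 and 4, and compound 2 goes against any clean split since it lies within the scatter of all three others. Nothing available on these compounds accounts for the flat result at this position.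

The compounds shown leave open whether the hydroxyl and the two methyl groups of compound 4 offset each other, which a plain 4-hydroxyphenyl group would separate. They also leave open whether the lower number of compound 3 extends to a 4-bromophenyl or 4-fluorophenyl group, and how a 4-aminophenyl group or a 4-carboxyphenyl group would read at the same carbon.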